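A dichlorophenyl swap on a carbonyl carbon

This account rests on a few compounds, and the source may have more. Where it says the series, first, only, none or still open, it means among the compounds named here.

- compound 1 `COc1cc(/C=C/C(=O)c2cccc(NC(=O)c3cccs3)c2)ccc1O`: 6.93 ug/mL
- compound 2 `COc1cc(/C=C/C(=O)c2cccc(NC(=O)c3ccc(Cl)cc3Cl)c2)ccc1O`: 12.8 ug/mL
- compound 3 `COc1cc(/C=C/C(=O)c2cccc(NC(=O)c3ccc(Cl)c(Cl)c3)c2)ccc1O`: not yet measured

In a functional assay on B16 cells (Mus musculus) for inhibition (a lower number here means a stronger inhibitor, a higher number a weaker inhibitor), compound 2 at 12.8 ug/mL stands within the scatter of compound 1 at 6.93 ug/mL and cannot be told apart from it. The change to compound 3 is this: 3,4-dichlorophenyl in place of 2,4-dichlorophenyl on a carbonyl carbon and the rest of the structure stays the same. Among the measured compounds shown here, one measured step touches that carbonyl carbon, a 1.8-fold higher number from compound 1 to compound 2 (0.27 log units; within the scatter), and it stays within the scatter. For the measured compounds named here, no measurement yet compares the two dichlorophenyl groups, so no step beyond the scatter is expected. The expected step is a 1.3-fold lower number from compound 2 to compound 3 (0.11 log units; within the scatter) in this assay and lies within the scatter. Compound 3 is estimated at 10 ug/mL, with an expected range from 5 ug/mL to 20 ug/mL for this estimate.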

Compound 3, half-maximal inhibitory concentration: 3.88 ug/mL
Estimate against measurement, compound 3: 2.6-fold (0.41 log units) above, and the stated range ends above it.
By their numbers in this assay, from the lowest: compounds 3, 1 and 2 (each within the scatter of the next, the first and the last beyond it).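

In this assay, the two dichlorophenyl groups on the carbonyl carbon hold the same atoms joined differently, yet they can be told apart (a 3.3-fold lower number from compound 2 to compound 3 (0.52 log units; beyond the scatter)). At this position, then, the placing of the two chlorines counts, and not only their presence. Thiophen-2-yl and 3,4-dichlorophenyl, by contrast, cannot be told apart (a 1.8-fold lower number from compound 1 to compound 3 (0.25 log units; within the scatter)), and nothing measured here accounts for the result.

Open, from the compounds shown here alone, is how a 4-chlorophenyl, a 3-chlorophenyl or a pyridyl group on the same carbonyl carbon would read in this assay.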